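The compounds below may be only part of what the source reports. "The series", "measured", "known", "first", "only" and "open" are said of these compounds alone.

Measured so far in a functional assay on 1321-N1 cells for agonist activity at P2Y purinoceptor 6 (Homo sapiens), read by scintillation counting and inositol phosphate accumulation; on this read-out higher numbers stand for an effect only at larger amounts of compound and lower numbers for an effect already at smaller amounts:
compound 1 `O=c1[nH]/c(=N\OCCCc2cccc([N+](=O)[O-])c2)ccn1[C@@H]1O[C@H](COP(=O)(O)OP(=O)(O)OP(=O)(O)O)[C@@H](O)[C@H]1O` — 9700 nM
compound 2 `O=c1[nH]/c(=N\OCCCc2cccnc2)ccn1[C@@H]1O[C@H](COP(=O)(O)OP(=O)(O)OP(=O)(O)O)[C@@H](O)[C@H]1O` — 2950 nM

Among the compounds with values here, compound 2 holds the lowest of the two numbers; the only other point is compound 1, and the step of a 3.3-fold lower number from compound 1 to compound 2 (0.52 log units; beyond the scatter) is the single measured comparison. Compound 3 `O=c1[nH]/c(=N\OCCCc2ccsc2)ccn1[C@@H]1O[C@H](COP(=O)(O)OP(=O)(O)OP(=O)(O)O)[C@@H](O)[C@H]1O` has not been measured. It differs from compound 2 by thiophen-3-yl in place of pyridin-3-yl on a saturated chain carbon, three bonds along the chain from an oxygen. Within the data shown here, the one measured step concerns the same chain position but a different exchange, a 3-nitrophenyl for the pyridin-3-yl, so it bears on compound 3 only as a sign that the terminal aromatic group at this place moves the read-out by a modest amount. Among the measured compounds shown here, no measured pair shows a six-membered to five-membered ring exchange. For compound 3 a step of roughly a 1.4-fold higher number from compound 2 to compound 3 (0.13 log units; within the scatter) is therefore expected, with direction uncertain and the range wide. Compound 3 is estimated at 4000 nM, between 1500 nM and 12000 nM.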

Compound 3, half-maximal effective concentration: 164 nM
Compound 3: middle estimate off by 24-fold (1.39 log units), on the high side; the whole stated range lies above it.
By their numbers in this assay, from the lowest: compound 3; then compound 2; then compound 1.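

In this assay the terminal aromatic group on the propyl chain now shows a far larger reach than the earlier pair suggested: thiophen-3-yl, a five-membered aromatic ring, gives an 18-fold lower number from compound 2 to compound 3 (1.25 log units; beyond the scatter) and also a 59-fold lower number from compound 1 to compound 3 (1.77 log units; beyond the scatter) in the same place. Within the data shown here, compound 3 therefore has the lowest number of the three, and both new steps are large, whereas the only earlier step was modest. Nothing at hand explains why this exchange has such an effect.

Still open, from the compounds shown here alone, is whether the drop belongs to the sulfur atom, the ring size or the point of attachment, which unsubstituted phenyl, furan-3-yl and thiophen-2-yl would help to separate. Going by these compounds, the chain length also remains open, since 2-(thiophen-3-yl)ethyl and 4-(thiophen-3-yl)butyl would show whether the thiophen-3-yl result holds on a shorter or a longer chain.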